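Trifluorophenyl Analogue and Host-Cell Toxicity

A few compounds are considered here, and "the series" means these few. Any claim that something is new, unique, unknown or untested is made for them only; others in the source may bear on it.

Compound 2 `COc1cccc(/C=C2\SC(=S)N(NS(=O)(=O)c3ccccc3)C2=O)c1` is the starting point. In a functional assay on HFF cells (Homo sapiens) for cytotoxicity (a higher number here means a weaker inhibitor, a lower number a stronger inhibitor), compound 2 gives > 100000 nM, which is a limit of the assay and not a number. Compound 1 `Cc1cccc(/C=C2\SC(=S)N(NS(=O)(=O)c3ccccc3)C2=O)c1` gives > 100000 nM in this assay, also a limit. Compound 3 `O=C1/C(=C/c2cc(F)ccc2F)SC(=S)N1NS(=O)(=O)c1ccccc1` gives > 100000 nM in this assay, again a limit. The step that the two limits leave unreadable from compound 1 to compound 2, the step that the two limits leave unreadable from compound 1 to compound 3 and the step that the two limits leave unreadable from compound 2 to compound 3 cannot be sized because of the limit of > 100000 nM in this assay, at which 3 of the 3 values shown sit. Compound 4 `O=C1/C(=C/c2cc(F)c(F)cc2F)SC(=S)N1NS(=O)(=O)c1ccccc1` differs from compound 2 by 2,4,5-trifluorophenyl in place of 3-methoxyphenyl on a double-bonded chain carbon bound to a double-bonded ring carbon. The two earlier changes at the same place left nothing readable, so no step beyond the scatter can be foreseen in this assay. Compound 4 is expected to give 100000 nM, within a range from 40000 nM to 300000 nM, most likely again only a limit. The estimated step of a number no higher from compound 2 to compound 4 (the limit leaves the size open) is accordingly expected to stay within the scatter.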

Compound 4, half-maximal inhibitory concentration: > 100000 nM
Compound 4 ended at the assay's limit (the forecaster's own chance of this, stated with the estimate: 85%); the middle value lies on the limit itself.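

No step can be read between compound 4 and compound 1, compound 2 or compound 3 in this assay, since each value is only a limit: the limit of > 100000 nM in this assay, at which 4 of the 4 values shown sit. From the compounds shown here alone, how far these aromatic groups differ in host-cell toxicity, if at all, stays open.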